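The source may report more compounds than this note shows. Statements on the series, on what has been measured and on what is new or still open speak of the compounds shown alone.

Of the compounds shown here, three have been tested in an ADME assay on MIA PaCa-2 cells (Homo sapiens) for cytotoxicity, read by MTT assay, with a stated time of 72 h; on this read-out higher numbers stand for weaker inhibition and lower numbers for stronger inhibition: compound 1 (`COc1ccc(C2=C(c3cc(OC)c(OC)c(OC)c3)C(=O)CC2C)cc1C(=O)O`), compound 2 (`C=CCOc1cc(C2=C(c3cc(OC)c(OC)c(OC)c3)C(=O)C(O)C2)ccc1OC`) and compound 3 (`COc1cc(C2=C(c3cc(C)c(OC)c(C)c3)C(OC(C)=O)CC2=O)cc(OC)c1OC`). Compound 1 gives > 100 ug/mL, which is a limit of the assay and not a number. Compound 3 gives > 100 ug/mL, which is also a limit. Compound 2 gives > 100 ug/mL, again a limit. Compound 2 therefore stands with the other two, and all three share (the limit of > 100 ug/mL in this assay, at which 3 of the 3 values shown sit). No measured number yet ranks them.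

Compound 4 (`COc1ccc(C2=C(c3cc(OC)c(OC)c(OC)c3)C(=O)C(O)C2)cc1Cl`) differs from compound 2 in one place: chloro in place of allyloxy on an aromatic carbon. This puts chloro in place of allyloxy on an aromatic carbon, ortho to a methoxy group. Among the measured compounds shown here, no measured pair of compounds differing in one place shows how large such a change might be in this assay. The expectation rests on compound 2, with its limit of > 100 ug/mL. The estimated a number no higher from compound 2 to compound 4 (the limit leaves the size open) is expected to stay within the usual scatter, with no clear direction. For compound 4 the expected value is 100 ug/mL, with an estimated range from 40 ug/mL to 200 ug/mL.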

Compound 4, half-maximal inhibitory concentration: > 100 ug/mL
Compound 4 ended at the assay's limit; the forecaster's own chance of this, stated with the estimate: 65%; the middle value lies on the limit itself.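

The step between compound 2 and compound 4 cannot be read, as both values are limits and not numbers: the limit of > 100 ug/mL in this assay, at which 4 of the 4 values shown sit.

The compounds shown leave open how chloro and allyloxy compare at this place, and none of the four yet has a number that ranks it.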